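A few compounds are considered here, and "the series" means these few. Any claim that something is new, unique, unknown or untested is made for them only; others in the source may bear on it.

Compound 1, `O=C(/C=C\c1ccc(O)cc1)N1N=C(c2ccncc2)OC1c1c[nH]c2ccccc12`, is examined in an ADME assay on A549 cells (Homo sapiens) for cytotoxicity, read by MTT assay, with a stated time of 48 h; a higher number here means a weaker inhibitor of growth, a lower number a stronger inhibitor of growth. There compound 1 gives only a limit, > 30 ug/mL, so the shared core carrying a 4-hydroxyphenyl group stands at the edge of what the assay can report rather than on a number. Going by the values given here, its one measured neighbour is compound 2, `O=C(/C=C\c1ccccc1[N+](=O)[O-])N1N=C(c2ccncc2)OC1c1c[nH]c2ccccc12`, which carries 2-nitrophenyl in place of 4-hydroxyphenyl on a double-bonded chain carbon bound to a double-bonded chain carbon. In this assay compound 2 also gives only a limit, > 30 ug/mL. The step that the two limits leave unreadable from compound 1 to compound 2 thus offers no size at all, since (the limit of > 30 ug/mL in this assay, at which 2 of the 2 values shown sit).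

The unmeasured compound 3, `O=C(/C=C\c1cccc(F)c1)N1N=C(c2ccncc2)OC1c1c[nH]c2ccccc12`, differs from compound 1 in one place: 3-fluorophenyl in place of 4-hydroxyphenyl on a double-bonded chain carbon bound to a double-bonded chain carbon. No measured step bears on this change in a readable way, the single step shown being hidden by the limit on both sides. For the step of a number no higher from compound 1 to compound 3 (the limit leaves the size open) nothing beyond the scatter is therefore expected. Compound 3 is estimated at 30 ug/mL, in a range from 15 ug/mL to 60 ug/mL, with another limit the likeliest report.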

Compound 3, concentration for 50% growth inhibition: > 30 ug/mL
Compound 3 was reported as a limit; the forecaster's own chance of this, stated with the estimate: 75%; the middle value sits exactly at the limit.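

The steps from compound 1 to compound 3 and from compound 2 to compound 3 cannot be read in this assay, as all three compounds sit at one limit: the limit of > 30 ug/mL in this assay, at which 3 of the 3 values shown sit.

The compounds shown leave open how 4-hydroxyphenyl, 2-nitrophenyl and 3-fluorophenyl compare in their effect on growth inhibition.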